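A few compounds are considered here, and "the series" means these few. Any claim that something is new, unique, unknown or untested is made for them only; others in the source may bear on it.

Compound 2 `CC1=C(SC(C)C(C)O)C(=O)c2ccccc2C1=O` is tested in a functional assay on MCF7 cells (Homo sapiens) for inhibition (on this read-out lower numbers stand for stronger inhibition and higher numbers for weaker inhibition), where it reaches only a limit of the assay, > 10000 nM. Compound 1 `CC1=C(SCCCCO)C(=O)c2ccccc2C1=O` gives 5780 nM in this assay. Going by the values given here, the one measured step, an at least 1.7-fold higher number from compound 1 to compound 2 (0.23 log units; that floor lies within the scatter), replaces the whole side chain and is capped by the limit of > 10000 nM in this assay, at which 1 of the 2 values shown sits. Compound 3 `CC1=C(SCC(C)O)C(=O)c2ccccc2C1=O` differs from compound 2 by hydrogen in place of methyl on a saturated chain carbon bound to a saturated chain carbon and a sulfur. Among the compounds with values here, no measured step matches this change, so nothing beyond the scatter is expected. Compound 3 is therefore estimated at 9000 nM, with a range from 3000 nM to 30000 nM. The expected step is an at least 1.1-fold lower number from compound 2 to compound 3 (0.04 log units; that floor lies within the scatter).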

Compound 3, half-maximal inhibitory concentration: 4610 nM
Compound 3: the middle estimate sits 2.0-fold (0.29 log units) above what was measured, and the stated range covers the measured number.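

In this assay, hydrogen in place of methyl on a saturated chain carbon bound to a sulfur gives an at least 2.1-fold lower number from compound 2 to compound 3 (0.33 log units; beyond the scatter), so this one methyl is enough on its own to shift the number, which the earlier whole-chain swap could not isolate. By contrast, 1-hydroxyethyl in place of 3-hydroxypropyl on that carbon gives a 1.3-fold lower number from compound 1 to compound 3 (0.10 log units; within the scatter), so these two chains are not told apart. The true size of the methyl step stays unknown, since compound 2 gives only a limit: the limit of > 10000 nM in this assay, at which 1 of the 3 values shown sits.

From the compounds shown here alone, what an amine or a carboxylic acid would do in place of the hydroxyl on this side chain remains open.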